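An Isomeric Step From Compound 1

The source may hold more compounds than are shown below. What is called first, only, known or untested is meant among the compounds shown, and "the series" means these compounds.

compound 1 `Clc1ccc2c(NCCNc3nccc(Cl)n3)ccnc2c1` at 2850 nM
compound 2 `Clc1ccc2c(NCCCCCCCCCCCCNc3nccc(Cl)n3)ccnc2c1` at 19400 nM

In a physicochemical assay for solubility, read by HPLC, measured as octanol-water partition, at pH 7.4 (on this read-out lower numbers stand for lower solubility and higher numbers for higher solubility), compound 1 holds the lower number and compound 2 the higher, a gap beyond the scatter. Compound 3 `Clc1ccc2c(NCCNc3ccnc(Cl)n3)ccnc2c1` has the same atoms as compound 1, joined differently, with 2-chloropyrimidin-4-yl in place of 4-chloropyrimidin-2-yl on an amine nitrogen. For the measured compounds named here, no measured pair shows this change, so no step beyond the scatter is expected in this assay here. The expected step is a 1.1-fold higher number from compound 1 to compound 3 (0.02 log units; within the scatter) in this estimate. For compound 3 the estimated value is 3000 nM with an expected range from 1200 nM to 7500 nM for the coming measurement.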

Compound 3, solubility: 2090 nM
Compound 3: middle estimate off by 1.4-fold (0.16 log units), on the high side; the range from low to high includes it.
By their numbers in this assay, from the lowest: compounds 3 and 1 (each within the scatter of the next); then compound 2.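

Swapping the chloropyrimidinyl group for its isomer on the amine nitrogen gives a 1.4-fold lower number from compound 1 to compound 3 (0.13 log units; within the scatter) in this assay, the first step shown between measured compounds. At this position, on this short chain, the isomeric change therefore produces no step beyond the scatter. No measurement shown offers a reason for this result.

From the compounds shown here alone, whether the same exchange would read alike on the longer chain of compound 2 remains open. So does the outcome of replacing the chlorine on either chloropyrimidinyl group with an amine or a carboxylic acid.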